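The compounds below may be only part of what the source reports. "The series", "measured", "known", "first", "only" and "open" are said of these compounds alone.

Within the data shown here, compound 2 `CN1CCCN(c2ccn3c(-c4ccc(NC(=O)c5ccc([N+](=O)[O-])o5)cc4)cnc3c2)CC1` is one of two compounds measured in a functional assay on MGC-803 cells (Homo sapiens) for antiproliferative activity, read by CCK-8 assay, with a stated time of 72 h (on this read-out lower numbers stand for stronger inhibition and higher numbers for weaker inhibition), and in that setting compound 2 gives 3580 nM, the higher of the two numbers. Its closest neighbour is compound 1 `O=C(Nc1ccc(-c2cnc3cc(N4CCN(C5CC5)CC4)ccn23)cc1)c1ccc([N+](=O)[O-])o1`, which in this assay gives 1650 nM; the step of a 2.2-fold higher number from compound 1 to compound 2 (0.34 log units; beyond the scatter) separates them, and that step consists of placing 4-methyl-1,4-diazepan-1-yl where 4-cyclopropylpiperazin-1-yl had stood on an aromatic carbon of the shared core.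

Compound 3 `O=C(Nc1ccc(-c2cnc3cc(Cl)ccn23)cc1)c1ccc([N+](=O)[O-])o1` has not yet been measured in this assay. It differs from compound 2 in one place: chloro in place of 4-methyl-1,4-diazepan-1-yl on an aromatic carbon. Among the measured compounds shown here, only the step from compound 1 to compound 2 bears on this change at all, and it exchanges one seven- or six-membered saturated ring for another rather than removing such a ring in favour of a single chlorine, so it speaks to the new step only loosely. On that thin basis compound 3 is expected to show the step of a 1.4-fold higher number from compound 2 to compound 3 (0.15 log units; within the scatter), with the direction uncertain and the range wide, and the estimate for compound 3 is 5000 nM, between 1500 nM and 20000 nM.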

Compound 3, half-maximal inhibitory concentration: 4620 nM
Beside the measured number, compound 3's estimate is 1.1-fold (0.03 log units) above it; the range from low to high includes it.
By their numbers in this assay, from the lowest: compound 1; then compounds 2 and 3 (each within the scatter of the next).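

In this assay, chloro in place of 4-methyl-1,4-diazepan-1-yl gives a 1.3-fold higher number from compound 2 to compound 3 (0.11 log units; within the scatter), so on this aromatic carbon, opposite the ring nitrogen, a single chlorine and the seven-membered ring cannot be told apart, and a saturated ring at this place is not needed for the activity that compound 2 shows. Against the 4-cyclopropylpiperazin-1-yl group the same chloro gives a 2.8-fold higher number from compound 1 to compound 3 (0.45 log units; beyond the scatter), which places compound 1 apart from both other compounds and makes 4-cyclopropylpiperazin-1-yl the only group shown here that stands out at this position, though only modestly. No measurement is available that accounts for this difference among the three groups.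

The compounds shown leave open whether the edge of compound 1 belongs to the piperazine ring or to its cyclopropyl group, since a piperazine bearing a methyl group or a hydrogen on its far nitrogen does not appear among them. They also leave open where a morpholine ring, an open-chain amine such as dimethylamino, or a small methoxy group at this carbon would fall relative to these three compounds.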